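Aryl change on the five-membered ring: compound 3 pending

The compounds below may be only part of what the source reports. "The series", "measured", "known", "first", "only" and "open" are said of these compounds alone.

Two compounds of the series carry numbers in an assay on CHO cells for displacement of a labelled ligand from adenosine receptor A3 (Homo sapiens), read by scintillation counting, with a stated time of 3 h; on this read-out lower numbers stand for stronger inhibition and higher numbers for weaker inhibition. Compound 1 `Cn1c(-c2ccc(F)cc2)nc2c(NC3CCCC3)ncnc21` gives 1140 nM. Compound 2 `CCn1c(-c2ccccc2)nc2c(NC3CCCCC3)ncnc21` gives 707 nM. Among the compounds with values here, the gap between compound 1 and compound 2 lies within the usual scatter, so neither stands apart from the other, and since compound 2 differs from compound 1 in more than one place no single-change step can be drawn from this pair.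

Compound 3 `Cn1c(-c2cccc(Cl)c2)nc2c(NC3CCCC3)ncnc21` is not yet measured. Its difference from compound 1 is 3-chlorophenyl in place of 4-fluorophenyl on an aromatic carbon, a 3-chlorophenyl in place of a 4-fluorophenyl on an aromatic carbon. Within the data shown here, no step between measured compounds that differ in one place is available to anchor this change. The expectation is therefore for a step no larger than the scatter, in either direction, and the estimated step is a 1.3-fold lower number from compound 1 to compound 3 (0.10 log units; within the scatter). Compound 3 is expected to give 900 nM, with a range from 300 nM to 2700 nM.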

Compound 3, inhibition constant: 514 nM
Beside the measured number, compound 3's estimate is 1.8-fold (0.24 log units) above it; the measured number falls inside the stated range.
By their numbers in this assay, from the lowest: compounds 3, 2 and 1 (each within the scatter of the next, the first and the last beyond it).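

In this assay, within the data shown here, the carbon between two ring nitrogen atoms gives the first single-change step: 3-chlorophenyl in place of 4-fluorophenyl gives a 2.2-fold lower number from compound 1 to compound 3 (0.35 log units; beyond the scatter). Among these compounds, the number at this position therefore moves with the aryl group, though only modestly, and this is the only step available there so far. The change swaps the halogen and its place on the phenyl ring together, so this pair cannot separate the two, and nothing at hand accounts for the step.

Still open, on these data alone, is how 4-chlorophenyl or 3-fluorophenyl would compare with compound 1 and compound 3, which would separate the halogen from its place on the ring. Also open, as far as these compounds go, is how this position would respond to a phenyl ring bearing an amine or a carboxylic acid.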